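The compounds below may be only part of what the source reports. "The series", "measured", "known", "first", "only" and "open" are said of these compounds alone.

Three compounds share one core and differ only in the aromatic ring attached to the sulfonyl sulfur. Compound 1 `COc1cc(-c2nc(-c3ccccc3)[nH]c2-c2ccnc(NCCCNS(=O)(=O)c3ccccc3)n2)ccc1Cl` carries an unsubstituted phenyl there; compound 2 `COc1cc(-c2nc(-c3ccccc3)[nH]c2-c2ccnc(NCCCNS(=O)(=O)c3ccc(F)cc3)n2)ccc1Cl` carries a 4-fluorophenyl; compound 3 `COc1cc(-c2nc(-c3ccccc3)[nH]c2-c2ccnc(NCCCNS(=O)(=O)c3cccc(F)c3)n2)ccc1Cl` carries a 3-fluorophenyl. In a functional assay on LOX IMVI cells (Homo sapiens) for cytotoxicity, read by MTT assay, with a stated time of 24 h (a lower number here means a stronger inhibitor, a higher number a weaker inhibitor), compound 1 gives 7470 nM, compound 2 gives 4530 nM, and compound 3 gives 5110 nM. Compound 3 thus sits second highest of the three numbers, though every gap among them is small: a 1.6-fold lower number from compound 1 to compound 2 (0.22 log units; within the scatter), a 1.5-fold lower number from compound 1 to compound 3 (0.16 log units; within the scatter) and a 1.1-fold higher number from compound 2 to compound 3 (0.05 log units; within the scatter), each within the scatter.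

Compound 4 `COc1ccc(S(=O)(=O)NCCCNc2nccc(-c3[nH]c(-c4ccccc4)nc3-c3ccc(Cl)c(OC)c3)n2)cc1` changes the same ring once more: 4-methoxyphenyl in place of 3-fluorophenyl on a sulfonyl sulfur. The measured steps that bear on this are those that altered a substituent on this sulfonyl-bound ring, and none of them moved the number beyond the scatter, so a substituent swap on that ring is expected to leave the value roughly where it is. For compound 4 in this assay the expected value is 5000 nM, between 2500 nM and 10000 nM, meaning a step of a 1.0-fold lower number from compound 3 to compound 4 (0.01 log units; within the scatter) that is expected to stay within the scatter.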

Compound 4, half-maximal inhibitory concentration: 1800 nM
Compound 4: the middle estimate sits 2.8-fold (0.44 log units) above what was measured; the measured number lies below the stated range.
By their numbers in this assay, from the lowest: compound 4; then compounds 2, 3 and 1 (each within the scatter of the next).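

Substituents on the ring held by the sulfonyl sulfur can move the number after all: in this assay, 4-methoxyphenyl gives steps beyond the scatter against all three earlier compounds (a 2.8-fold lower number from compound 3 to compound 4 (0.45 log units; beyond the scatter); a 2.5-fold lower number from compound 2 to compound 4 (0.40 log units; beyond the scatter); a 4.2-fold lower number from compound 1 to compound 4 (0.62 log units; beyond the scatter)). The outcome at this position therefore depends on which group is placed there, since fluoro in place of hydrogen stayed within the scatter while methoxy in place of hydrogen did not. Nothing measured here accounts for the lower number of compound 4.

From the compounds shown here alone, it remains open whether this drop belongs to methoxy alone or would also come with a 4-methylphenyl or a 4-aminophenyl on the sulfonyl sulfur. Going by these compounds, it is also open whether a 3-methoxyphenyl there would match the 4-methoxyphenyl of compound 4.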